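A Single Stereocentre Inverted in Compound 2

A few compounds are considered here, and "the series" means these few. Any claim that something is new, unique, unknown or untested is made for them only; others in the source may bear on it.

Of the compounds shown here, two built on a shared core have so far been measured in a functional assay on Ramos cells (Homo sapiens) for antiproliferative activity; a lower number here means a stronger inhibitor, a higher number a weaker inhibitor. In that test, compound 1 `Nc1ncnc2c1c(-c1ccc(NC(=O)c3ccccc3)cc1)cn2[C@H]1CCN(C[C@@H]2CO2)C1` gives 2250 nM. Compound 2 `Nc1ncnc2c1c(-c1cc3ccccc3o1)cn2[C@H]1CCN(C[C@@H]2CO2)C1` gives 6740 nM in this assay, the higher number of the pair and so the weaker result, and its gap to compound 1 lies beyond the usual scatter.

The next compound is compound 3 `Nc1ncnc2c1c(-c1cc3ccccc3o1)cn2[C@H]1CCN(C[C@H]2CO2)C1`, which departs from compound 2 only in its drawn geometry: the two compounds have the same atoms and bonds and differ only in configuration as drawn: 1 of 2 stereo elements differ; a stereocentre at a saturated ring carbon is drawn R in compound 2 and S in compound 3. Nothing leaves and nothing enters, so the two compounds have the same atoms and bonds.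

Among the measured compounds shown here, the two measured compounds differ in more than this one stereocentre, and no measured pair shows what inverting it does. The expectation therefore starts from compound 2 at 6740 nM, with no direction favoured and a modest change beyond the scatter left possible. The expected step is a 1.0-fold lower number from compound 2 to compound 3 (0.02 log units; within the scatter), a size that would most likely stay within the scatter. For compound 3 the estimated value is 6500 nM, with an expected range from 2800 nM to 15000 nM.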

Compound 3, half-maximal inhibitory concentration: 1650 nM
Beside the measured number, compound 3's estimate is 3.9-fold (0.60 log units) above it; measured number outside the range, below it.
By their numbers in this assay, from the lowest: compounds 3 and 1 (each within the scatter of the next); then compound 2.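

In this assay, inverting the one stereocentre at the saturated ring carbon from R to S gives a 4.1-fold lower number from compound 2 to compound 3 (0.61 log units; beyond the scatter), so this position is sensitive to its drawn configuration, even though the step is modest in size. Among the compounds shown here, the earlier pair, compound 1 and compound 2, differed in more than this stereocentre and could not isolate its contribution; this is the first measured step to do so, and it shows that the geometry at this carbon alone can move the antiproliferative read-out beyond the scatter. The step can be attributed to configuration rather than to any gain or loss of atoms, because nothing else separates the two structures: the fact that compounds 2 and 3 differ only in the configuration as drawn

What the compounds shown leave open is whether the S configuration at this carbon would bring a similar step when the benzamide-bearing aryl group of compound 1 replaces the benzofuran-type group of compound 2 and compound 3, and what inverting the other stereo element would do. They also leave open how the activity would respond if a hydroxyl group or an amine were carried at this ring carbon, and they say nothing about why the S configuration gives the lower number.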